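Moving the methyl on the benzoxazole of compound 2

The source may report more compounds than this note shows. Statements on the series, on what has been measured and on what is new or still open speak of the compounds shown alone.

Measured so far in a functional assay on CHO cells for agonist activity at prostaglandin E2 receptor EP2 subtype (Rattus norvegicus), read by cAMP accumulation and immunoassay, with a stated time of 10 min; a higher number here means that more compound is needed for the effect, a lower number that less compound is needed:
compound 1, `O=C(O)c1csc(SCCN2C(=O)CC[C@@H]2/C=C/[C@@H](O)Cc2cccc(-c3ccccc3)c2)n1`: 1800 nM
compound 2, `Cc1ccc2oc(-c3cccc(C[C@H](O)/C=C/[C@H]4CCC(=O)N4CCSc4nc(C(=O)O)cs4)c3)nc2c1`: > 10000 nM, a limit of the assay and not a number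

Compound 2 therefore stands at the limit of > 10000 nM in this assay, at which 1 of the 2 values shown sits; its true value is not known, only that it does not fall under this line. Among the compounds with values here, the single measured step, an at least 5.5-fold higher number from compound 1 to compound 2 (0.74 log units; beyond the scatter), is at least modest and beyond the scatter, but since it ends at a limit its full size remains open.

Compound 3 is `Cc1cccc2oc(-c3cccc(C[C@H](O)/C=C/[C@H]4CCC(=O)N4CCSc4nc(C(=O)O)cs4)c3)nc12`. It differs from compound 2 only in 4-methyl-1,3-benzoxazol-2-yl in place of 5-methyl-1,3-benzoxazol-2-yl on an aromatic carbon, so the two share every atom and differ in how they are joined. Within the data shown here, no measured step moves a methyl on this group, and the only step that bears on it is an at least 5.5-fold higher number from compound 1 to compound 2 (0.74 log units; beyond the scatter), which left compound 2 at the limit. The step that the limit leaves unreadable from compound 2 to compound 3 is therefore expected to be none beyond the scatter. Compound 3 is expected at about 12000 nM in this assay, within 3000 nM to 40000 nM, with a real chance that again only a limit is reported.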

Compound 3, half-maximal effective concentration: 8500 nM
For compound 3 the middle estimate is 1.4-fold (0.15 log units) above the measured one, and the stated range covers the measured number.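

With 4-methyl-1,3-benzoxazol-2-yl on the aromatic carbon, this assay now gives a full number for a methyl-bearing benzoxazole in place of phenyl, and that change reads as a 4.7-fold higher number from compound 1 to compound 3 (0.67 log units; beyond the scatter), a modest step. The shift of the methyl itself can be read only as an at least 1.1-fold lower number from compound 2 to compound 3 (0.07 log units; that floor lies within the scatter), so the data do not show that 4-methyl-1,3-benzoxazol-2-yl and 5-methyl-1,3-benzoxazol-2-yl differ in this assay. Compound 2 holds a limit and not a number, which leaves the true size of that shift unread: the limit of > 10000 nM in this assay, at which 1 of the 3 values shown sits.

The compounds shown leave open whether the higher number seen against compound 1 comes with the benzoxazole itself or with its methyl, since a plain 1,3-benzoxazol-2-yl does not stand among them. They also leave open whether a chlorine or a methoxy in place of the methyl on the benzoxazole would bring the number closer to that of compound 1.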